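From a Saturated Ring to a Difluorophenyl Amide

The source may report more compounds than this note shows. Statements on the series, on what has been measured and on what is new or still open speak of the compounds shown alone.

Measured compounds:
compound 1 `Cc1cc(C(=O)NCc2cccnc2)nn1Cc1cc(Cl)ccc1OCc1ccccc1`: 50.1 nM
compound 2 `Cc1cc(NC(=O)C2CCOC2)nn1Cc1cc(Cl)ccc1OCc1ccccc1`: 39.8 nM
compound 3 `Cc1cc(NC(=O)C2CCOCC2)nn1Cc1cc(Cl)ccc1OCc1ccccc1`: 63.1 nM

The three compounds were tested in an assay on CHO-K1 cells for displacement of a labelled ligand from prostaglandin E2 receptor EP1 subtype (Homo sapiens); a lower number here means a stronger inhibitor, a higher number a weaker inhibitor. Compound 3 has the top number of the three, yet the steps of a 1.3-fold higher number from compound 1 to compound 3 (0.10 log units; within the scatter) and a 1.6-fold higher number from compound 2 to compound 3 (0.20 log units; within the scatter) both lie within the scatter, so no real separation between the three is visible.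

Compound 4 `Cc1cc(NC(=O)c2c(F)cccc2F)nn1Cc1cc(Cl)ccc1OCc1ccccc1` has not yet been measured. Relative to compound 3 it carries 2,6-difluorophenyl in place of oxan-4-yl on a carbonyl carbon. For the measured compounds named here, only one measured step alters the group on that carbonyl carbon, namely a 1.6-fold higher number from compound 2 to compound 3 (0.20 log units; within the scatter), and it stayed within the scatter; no measured step exchanges a saturated ring for an aromatic one, so there is no direct precedent for this change. With the whole measured set spanning less than the scatter, the expectation for compound 4 in this assay is a step of a 1.3-fold lower number from compound 3 to compound 4 (0.10 log units; within the scatter), that is, none beyond the scatter. The estimated value for compound 4 is 50 nM, with a range from 15 nM to 170 nM.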

Compound 4, half-maximal inhibitory concentration: 12.6 nM
Compound 4: the middle estimate sits 4.0-fold (0.60 log units) above what was measured; measured number below the stated range.
By their numbers in this assay, from the lowest: compound 4; then compounds 2, 1 and 3 (each within the scatter of the next).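

In this assay, the group on the carbonyl carbon whose other neighbour is the amide-type nitrogen proves able to move the number beyond the scatter: 2,6-difluorophenyl in place of the saturated rings gives a 5.0-fold lower number from compound 3 to compound 4 (0.70 log units; beyond the scatter) and a 3.2-fold lower number from compound 2 to compound 4 (0.50 log units; beyond the scatter), whereas exchanging one saturated ring for the other did not. The same amide also separates from the pyridin-3-ylmethyl carbamoyl group, with a 4.0-fold lower number from compound 1 to compound 4 (0.60 log units; beyond the scatter), which makes compound 4 the strongest inhibitor of the four. No data on hand speak to what lies behind this gain.

The compounds shown do not separate the contribution of the aromatic ring from that of its two fluorine atoms, a question that a plain phenyl on the same carbonyl carbon would address. From the compounds shown here alone, whether a pyridine ring there would serve equally also remains open.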